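The source may report more compounds than this note shows. Statements on the series, on what has been measured and on what is new or still open speak of the compounds shown alone.

Compound 1 `N#Cc1ccc(NC(=O)c2ccc(-c3cccnc3)cc2O)cc1`: 6660 nM
Compound 2 `COc1ccc(C(=O)Nc2ccc(C#N)cc2)c(O)c1`: 5470 nM

In a functional assay on HL-60 cells (Homo sapiens) for cytotoxicity, read by luminescence and CellTiter-Glo, with a stated time of 3 days (on this read-out lower numbers stand for stronger inhibition and higher numbers for weaker inhibition), compound 2 gives 5470 nM, which stands level, within the scatter, with compound 1. Compound 3 `N#Cc1ccc(NC(=O)c2ccc(F)cc2O)cc1` has fluoro in place of methoxy on an aromatic carbon, meta to a hydroxy group and para to a large group (fluoro in place of methoxy on an aromatic carbon). Within the data shown here, the only measured step that bears on this change is at that same carbon, a 1.2-fold lower number from compound 1 to compound 2 (0.09 log units; within the scatter), so no shift beyond the scatter is expected. For compound 3 the expected step is a 1.2-fold higher number from compound 2 to compound 3 (0.07 log units; within the scatter). Compound 3 is estimated at 6500 nM, with an expected range of 2500 nM to 15000 nM.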

Compound 3, half-maximal inhibitory concentration: 1380 nM
Beside the measured number, compound 3's estimate is 4.7-fold (0.67 log units) above it, outside the stated range (below it).
By their numbers in this assay, from the lowest: compound 3; then compounds 2 and 1 (each within the scatter of the next).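

In this assay this aromatic carbon, meta to a hydroxy group and para to a large group, turns out to be sensitive to the choice of group: fluoro brings a 4.0-fold lower number from compound 2 to compound 3 (0.60 log units; beyond the scatter) and a 4.8-fold lower number from compound 1 to compound 3 (0.68 log units; beyond the scatter). The earlier pair, with methoxy and pyridin-3-yl, had stood level within the scatter and gave no sign of this. No supporting evidence is available to explain the gain.

As far as these compounds go, it remains open whether plain hydrogen, chloro or an amine at this carbon would match fluoro or fall back towards methoxy and pyridin-3-yl. From the compounds shown here alone, whether the gain from fluoro would persist with changes elsewhere on the shared core also remains open.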